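Compound 3: trifluoromethyl in place of carbamoyl

The compounds below may be only part of what the source reports. "The series", "measured", "known", "first", "only" and "open" are said of these compounds alone.

Measured in an ADME assay on TZM cells (Homo sapiens) for cytotoxicity, read by XTT assay, with a stated time of 4 days; a higher number here means that more compound is tolerated, a lower number that less compound is tolerated:
- compound 1 `Cc1cc(/C=C/C#N)cc(C)c1Oc1cc(Nc2ccc(C#N)cc2)c(N)cc1C(N)=O` gives the limit > 23600 nM with no number
- compound 2 `Cc1cc(CCC#N)cc(C)c1Oc1cc(Nc2ccc(C#N)cc2)c(N)cc1CO` gives the limit > 23800 nM with no number

Compound 1 therefore stands at a limit > 23600 nM in this assay and has no exact value. Compound 3 `Cc1cc(/C=C/C#N)cc(C)c1Oc1cc(Nc2ccc(C#N)cc2)c(N)cc1C(F)(F)F` carries trifluoromethyl in place of carbamoyl on an aromatic carbon. Among the compounds with values here, no measured step tests this change. In this assay the expected result is a small fall in tolerated concentration or none beyond the scatter, with an estimated at least 1.3-fold lower number from compound 1 to compound 3 (0.11 log units; that floor lies within the scatter) as the step. Compound 3 is expected at 18000 nM with an estimated range from 5000 nM to 25000 nM and may also return only a limit.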

Compound 3, half-maximal cytotoxic concentration: 15000 nM
Beside the measured number, compound 3's estimate is 1.2-fold (0.08 log units) above it; low and high end bracket the measured number.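

Trifluoromethyl in place of carbamoyl on an aromatic carbon gives the only exact number shown in this assay, and the change reads as an at least 1.5-fold lower number from compound 1 to compound 3 (0.19 log units; that floor lies within the scatter). This step is only a floor, and a real fall cannot be claimed from it, because compound 1 stands at a limit: the limit of > 23600 nM in this assay, at which 1 of the 3 values shown sits.

From the compounds shown here alone, the true size of the gap from compound 1 to compound 3 stays open. So does the reading in this assay for a carboxylic acid or an amine on this same aromatic carbon.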